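A few compounds are considered here, and "the series" means these few. Any claim that something is new, unique, unknown or untested is made for them only; others in the source may bear on it.

Measured compounds in a functional assay on NUGC-3 cells (Homo sapiens) for cytotoxicity, read by sulforhodamine B assay, tested at 10 uM; a lower number here means less inhibition, a higher number more inhibition at the concentration tested (going by the name of the read-out):
compound 1 `CC(=O)OC[C@H]1O[C@@H](n2cc(-c3cc(-c4ccccc4)no3)c(=O)[nH]c2=O)C[C@@H]1OC(C)=O`, 87.6%
compound 2 `CCc1ccc(-c2cc(-c3cn([C@H]4C[C@H](OC(C)=O)[C@@H](COC(C)=O)O4)c(=O)[nH]c3=O)on2)cc1`, 72.6%
compound 3 `CC(C)(C)c1ccc(Cn2cc(-c3cn([C@H]4C[C@H](O)[C@@H](CO)O4)c(=O)[nH]c3=O)nn2)cc1`, 94.8%

Compound 3 carries the highest of the three numbers in this assay; compound 1 sits within the scatter of it, compound 2 beyond it.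

Compound 4 `O=c1[nH]c(=O)n([C@H]2C[C@H](O)[C@@H](CO)O2)cc1-c1cn(Cc2ccccc2)nn1` differs from compound 3 in one place: hydrogen in place of tert-butyl on an aromatic carbon.

Among the compounds with values here, the one measured step that bears on an alkyl group on an aromatic carbon is a number 15 percentage points lower from compound 1 to compound 2 (beyond the scatter), where adding an alkyl group cost a modest amount. The change to compound 4 runs the other way, removing an alkyl group, but compound 3 already sits near the top of the read-out, so little room remains upward.

Compound 4 is therefore expected at about 91%, with a range from 80% to 99%. The expected step of a number 3.8 percentage points lower from compound 3 to compound 4 (within the scatter) is estimated to stay within the scatter.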

Compound 4, a percentage reported as inhibition, at one concentration (the size of the read-out at that concentration, not a potency): 95.6%
Compound 4: the middle estimate sits 4.6 percentage points below what was measured; measured number inside the range.
By their numbers in this assay, from the lowest: compound 2; then compounds 1, 3 and 4 (each within the scatter of the next).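

In this assay, replacing 4-(tert-butyl)phenyl with phenyl gives a number 0.8 percentage points higher from compound 3 to compound 4 (within the scatter), so at this position the tert-butyl group is not required to keep the number high in this pair. The earlier alkyl step, a number 15 percentage points lower from compound 1 to compound 2 (beyond the scatter), lies beyond the scatter but on a different core, and it does not carry over to this position. No available data explain the new step.

On these data alone, whether an amine or a carboxylic acid on this aromatic carbon would lower the number stays open. Also open, as far as these compounds go, is whether compound 3 and compound 4 would separate at a lower tested concentration.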